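Phenyl in place of methyl on the methylated core

A few compounds are considered here, and "the series" means these few. Any claim that something is new, unique, unknown or untested is made for them only; others in the source may bear on it.

Three compounds have been run in an assay on isolated protein for inhibition of ribosomal protein S6 kinase alpha-5 (Homo sapiens), read by mobility shift assay, tested at 30 uM; on this read-out lower numbers stand for less inhibition and higher numbers for more inhibition at the one concentration tested (going by the name of the read-out). Compound 1 `Cc1cc2[nH]nc(N)c2c(=O)[nH]1` gives 56%, and compound 2 `COc1cccc(-c2cc3[nH]nc(N)c3c(=O)[nH]2)c1` gives 49%; these two values lie within the usual scatter of each other. Compound 3 `Cc1cc2c(c(N)nn2C)c(=O)[nH]1` gives 4%, the lowest of the three numbers, and its gap to both compound 1 and compound 2 is beyond the scatter. Among the compounds with values here, the single one-place step measured so far, a number 52 percentage points lower from compound 1 to compound 3 (beyond the scatter), is a large loss tied to methyl in place of hydrogen on an aromatic nitrogen.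

Compound 4 `Cn1nc(N)c2c(=O)[nH]c(-c3ccccc3)cc21` keeps that methylated nitrogen of compound 3 and differs from it by phenyl in place of methyl on an aromatic carbon, on the aromatic carbon next to the ring nitrogen. Within the data shown here, no measured step covers a phenyl for methyl exchange at this position; the closest hint is that compound 1 with methyl and compound 2 with a methoxyphenyl show values within the scatter of each other. On that basis the exchange is expected to carry little weight, and the low level of compound 3 is expected to persist in this assay. The estimated step of a number 2 percentage points higher from compound 3 to compound 4 (within the scatter) is expected to stay within the scatter. Compound 4 is therefore estimated at 6%, with a range from 0% to 20%.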

Compound 4, a percentage reported as inhibition, at one concentration (the size of the read-out at that concentration, not a potency): 9%
Compound 4: middle estimate off by 3 percentage points, on the low side; measured number inside the range.
By their numbers in this assay, from the lowest: compounds 3 and 4 (each within the scatter of the next); then compounds 2 and 1 (each within the scatter of the next).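

In this assay, the exchange on the aromatic carbon next to the ring nitrogen now has a direct reading on the methylated core: a number 5 percentage points higher from compound 3 to compound 4 (within the scatter) shows that phenyl in place of methyl, six heavy atoms for one, leaves the number within the scatter. On this core, the added six-membered aromatic ring of carbon only therefore gives no measurable recovery of the loss seen in a number 52 percentage points lower from compound 1 to compound 3 (beyond the scatter) and the low level stays in place. The data at hand offer no explanation for either step.

On these data alone, it remains open whether plain phenyl on this aromatic carbon would read the same on the core of compound 1, with hydrogen in place of methyl on the aromatic nitrogen. Also open, as far as these compounds go, is whether an amine or a carboxylic acid on that carbon of the methylated core, or an ethyl group in place of methyl on the aromatic nitrogen, would shift the number in this assay beyond the scatter.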